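This account rests on a few compounds, and the source may have more. Where it says the series, first, only, none or still open, it means among the compounds named here.

Measured so far in an ADME assay on BJ cells (Homo sapiens) for cytotoxicity, read by CellTiter-Glo and resazurin assay, with a stated time of 72 h; a lower number here means that less compound is needed, a higher number that more compound is needed for the effect:

compound 1, `CC(C)N(Cc1cccc(OCCCCCC(=O)O)c1)C(=O)c1ccc(-c2ccc(Cl)c(Cl)c2)cc1` — > 26000 nM
compound 2, `CCOC(=O)CCCCCOc1cccc(CN(C(=O)c2ccc(-c3cnc(OC)nc3OC)cc2)C(C)C)c1` — > 26000 nM

Compound 1 gives only a limit of the assay in this assay, > 26000 nM, and no number. Compound 2 likewise gives only a limit in this assay, > 26000 nM, not a number. Compound 2 therefore stands at the top of what the assay reports, which is where both values shown sit: the limit of > 26000 nM in this assay, at which 2 of the 2 values shown sit. For the measured compounds named here, no step between measured compounds is available, so nothing in these two values tells how a change on the aromatic carbon shifts the read-out.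

Compound 3, `CCOC(=O)CCCCCOc1cccc(CN(C(=O)c2ccc(-c3cccc(OC(F)(F)F)c3)cc2)C(C)C)c1`, differs from compound 2 in one place: 3-(trifluoromethoxy)phenyl in place of 2,4-dimethoxypyrimidin-5-yl on an aromatic carbon. With both measured compounds at the limit, the expectation for compound 3 is no step beyond the scatter, that is a result again at or near the limit, with the step from compound 2 estimated as a step that the limit leaves unreadable from compound 2 to compound 3. Compound 3 is thus expected to give about 30000 nM in this assay, in a range from 10000 nM to 100000 nM, most likely reported only as a limit.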

Compound 3, half-maximal effective concentration: > 26000 nM
Compound 3: no number, only a limit; the forecaster's own chance of this, stated with the estimate: 75%; the middle value does not contradict the limit.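

Compound 3 gives only a limit in this assay, > 26000 nM, not a number. For the compounds shown here, no step from compound 2 to compound 3 can be read, and the series sits at one point: the limit of > 26000 nM in this assay, at which 3 of the 3 values shown sit. The compounds shown leave open whether 3-(trifluoromethoxy)phenyl in place of 2,4-dimethoxypyrimidin-5-yl shifts the read-out at all, and at what concentration any of them reaches the half-maximal effect.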